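The source may hold more compounds than are shown below. What is called first, only, known or untested is meant among the compounds shown, and "the series" means these compounds.

Measured so far:
compound 1, `C/C=C/C=C/C(=O)N[C@H](C(=O)NCCCCCCCCCCCC)[C@@H](C)O` — > 200000 nM
compound 2, `CCCCCCCCCCCCNC(=O)[C@@H](NS(=O)(=O)c1ccc(C)cc1)[C@@H](C)O` — 31600 nM
compound 3, `C/C=C/C=C/C(=O)N[C@H](C(=O)NCCCCCCCCCCCCCC)[C@@H](C)O` — > 200000 nM

In a functional assay on SiHa cells (Homo sapiens) for cytotoxicity, read by MTT assay, with a stated time of 48 h (a higher number here means a weaker inhibitor, a lower number a stronger inhibitor), compound 1 gives only a limit of the assay, > 200000 nM. Compound 3 likewise gives only a limit in this assay, > 200000 nM. Compound 2, by contrast, gives a number in this assay: 31600 nM.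

Compound 1 and compound 2 differ by (4-methylphenyl)sulfonyl in place of (penta-1,3-dien-1-yl)carbonyl on an amine nitrogen, and the step is an at least 6.3-fold lower number from compound 1 to compound 2 (0.80 log units; beyond the scatter). Compound 1 and compound 3 differ by ethyl in place of hydrogen on a saturated chain carbon, ten or more bonds along the chain from an amide-type nitrogen; here a step that the two limits leave unreadable from compound 1 to compound 3, since both sit at the limit of > 200000 nM in this assay, at which 2 of the 3 values shown sit.

Compound 4, `CCCCCCCCCCCCCCNC(=O)[C@@H](NS(=O)(=O)c1ccc(C)cc1)[C@@H](C)O`, is not yet measured. It differs from compound 3 by (4-methylphenyl)sulfonyl in place of (penta-1,3-dien-1-yl)carbonyl on an amine nitrogen, the same change that turns compound 1 into compound 2. Resting on an at least 6.3-fold lower number from compound 1 to compound 2 (0.80 log units; beyond the scatter), the expected step is an at least 6.6-fold lower number from compound 3 to compound 4 (0.82 log units; beyond the scatter). Compound 4 is therefore estimated at 30000 nM, between 10000 nM and 100000 nM.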

Compound 4, half-maximal inhibitory concentration: 19200 nM
Beside the measured number, compound 4's estimate is 1.6-fold (0.19 log units) above it; measured number inside the range.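

In this assay, (4-methylphenyl)sulfonyl in place of (penta-1,3-dien-1-yl)carbonyl on the amine nitrogen again gives a step beyond the scatter, here an at least 10-fold lower number from compound 3 to compound 4 (1.01 log units; beyond the scatter). The change therefore carries over from one core to the other in direction, but how far its size is the same on the two cores cannot be said: the same change on two cores in this assay, an at least 6.3-fold lower number (0.80 log units; beyond the scatter) from compound 1 to compound 2 and an at least 10-fold lower number (1.01 log units; beyond the scatter) from compound 3 to compound 4; the limit leaves it open whether they differ. With (4-methylphenyl)sulfonyl in place, ethyl in place of hydrogen on a saturated chain carbon gives a 1.6-fold lower number from compound 2 to compound 4 (0.22 log units; within the scatter), so this pair shows no readable effect of that chain change.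

The compounds shown leave open whether a phenylsulfonyl group without the methyl, or an alkylsulfonyl group, would give a similar step. They also leave open whether a much shorter or longer chain would move the number beyond the scatter.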